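Chain extension in the alkynyl benzyl ether acids

The source may hold more compounds than are shown below. What is called first, only, known or untested is meant among the compounds shown, and "the series" means these compounds.

Going by the values given here, compound 3, `CCCCCCCC#CCOCc1ccc(C(=O)O)cc1`, gives 6000 nM in an assay on isolated protein for inhibition of Arachidonate 12-lipoxygenase (Sus scrofa) (on this read-out lower numbers stand for stronger inhibition and higher numbers for weaker inhibition), the highest of the numbers measured so far. Compound 2, `CCCCCCCCCCC#CCOCc1ccc(C(=O)O)cc1`, gives 60 nM in this assay. Among the compounds with values here, the one measured step, a 100-fold higher number from compound 2 to compound 3 (2.00 log units; beyond the scatter), is large. Compound 1, `CCCCCCCCCCCCCCC#CCOCc1ccc(CCC(=O)O)cc1`, gives > 10000 nM in this assay, a limit of the assay and not a number; it stands at the limit of > 10000 nM in this assay, at which 1 of the 3 values shown sits.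

Compound 4, `CCCCCCCCCCCCCCC#CCOCc1ccc(C(=O)O)cc1`, differs from compound 3 by heptyl in place of hydrogen on a saturated chain carbon, seven bonds along the chain from a triple-bonded carbon. Within the data shown here, the only measured step that bears on this change is the one from compound 2 to compound 3, which runs in the opposite direction: removing propyl at the same place gave a large rise in the number. Adding heptyl at that place therefore passes through the chain length of compound 2 and on to a longer chain. Whether the gain continues past compound 2 is not shown by any measured step; compound 1, which carries the long chain together with a different acid arm, sits at the limit, but no step connects it to the other compounds.

The expectation is a large fall in the number, a 30-fold lower number from compound 3 to compound 4 (1.48 log units; beyond the scatter), with the estimate for compound 4 in this assay at 200 nM, between 30 nM and 3000 nM.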

Compound 4, half-maximal inhibitory concentration: > 10000 nM
Compound 4: only a limit was reported (the forecaster's own chance of this, stated with the estimate: 10%); middle value at least 50-fold (1.69 log units) away from the limit.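

Compound 4 gives only a limit of the assay and not a number in this assay: the limit of > 10000 nM in this assay, at which 2 of the 4 values shown sit. Butyl in place of hydrogen on a saturated chain carbon gives an at least 160-fold higher number from compound 2 to compound 4 (2.22 log units; beyond the scatter), so among compounds 2, 3 and 4 the gain seen with the added propyl does not carry on to the longer chain, and the number does not simply fall as this chain grows. Heptyl in place of hydrogen gives an at least 1.6-fold higher number from compound 3 to compound 4 (0.22 log units; that floor lies within the scatter), a floor within the scatter, so compound 3 and compound 4 cannot be put in order, and the step from compound 1 to compound 4 cannot be read.

Still open, as far as these compounds go, is how the number behaves at intermediate chain lengths, on either side of the chain of compound 2, and so how narrow the favourable range is. Also open, from the compounds shown here alone, are whether the 2-carboxyethyl arm would be accepted on the chain of compound 2, and whether a phenyl or hydroxyl group at the chain end would restore inhibition on the longer chain.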